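This account rests on a few compounds, and the source may have more. Where it says the series, first, only, none or still open, it means among the compounds named here.

Compound 1 `SC1=NC(n2nc(-c3ccccc3)nc2-c2ccccc2)=CC(c2ccc(Cl)cc2)N1` is tested in a functional assay on the whole organism with Mus musculus as the target, in the maximal electroshock model, with a stated time of 0.5 h (a higher number here means that more compound is needed for the effect, a lower number that less compound is needed), where compound 1 gives 30 mg/kg. Its closest relative, compound 3 `SC1=NC(n2nc(-c3ccccc3)nc2-c2ccccc2)=CC(c2ccc(-c3ccco3)cc2)N1`, gives 30 mg/kg, and the step of no change at the digits printed from compound 1 to compound 3 (within the scatter) shows that swapping the group on that outer ring made no difference here. Compound 2 `COc1ccc(C2C=C(n3cc(-c4ccccc4)nc3-c3ccccc3)N=C(S)N2)cc1`, with a different outer ring substituent, gives 100 mg/kg, a number beyond the scatter above the other two. So compound 1 stands level with compound 3, and the two together sit lowest of the three.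

Compound 4 `SC1=NC(n2nc(-c3ccccc3)nc2-c2ccccc2)=CC(c2ccc(Br)cc2)N1` differs from compound 1 by bromo in place of chloro on an aromatic carbon. Going by the values given here, no measured step covers a swap of one halogen for another, but the single change tried at this spot, no change at the digits printed from compound 1 to compound 3 (within the scatter), moved nothing. For compound 4 the expectation is therefore a step of no change at the digits printed from compound 1 to compound 4 (within the scatter), with no change beyond the scatter. Compound 4 is estimated at 30 mg/kg, within a range from 15 mg/kg to 60 mg/kg.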

Compound 4, minimum effective dose: 100 mg/kg
Compound 4: the middle estimate sits 3.3-fold (0.52 log units) below what was measured; the whole stated range lies below it.
By their numbers in this assay, from the lowest: compounds 1 and 3 (each within the scatter of the next); then compounds 2 and 4 (each within the scatter of the next).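

The position is not indifferent to its group: bromo in place of chloro gives a 3.3-fold higher number from compound 1 to compound 4 (0.52 log units; beyond the scatter), whereas furan-2-yl in place of chloro had changed nothing. Bromo in place of furan-2-yl gives a 3.3-fold higher number from compound 3 to compound 4 (0.52 log units; beyond the scatter), so here a swap between two single halogen atoms counts for more than the swap to a whole added ring. No measured evidence explains this step.

Going by these compounds, it remains open whether fluoro, iodo, methyl or an amine on this carbon would behave like chloro or like bromo. With so few groups, no trend across this position can yet be drawn.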